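The compounds below may be only part of what the source reports. "The series", "measured", "known", "first", "only" and "open" are said of these compounds alone.

Compound 2, `C[n+]1ccn(CCCC#N)c1/C=N/O`, is one of three measured compounds. In a physicochemical assay for lipophilicity (on this read-out lower numbers stand for lower lipophilicity and higher numbers for higher lipophilicity), compound 2 reaches only the lower limit of the method, < -3, so no number is known for it. Compound 1, `COC(C)CCOCn1cc[n+](C)c1/C=N/O`, gives -2.22 in this assay, and compound 3, `COC(=O)CCCCCn1cc[n+](C)c1/C=N/O`, gives -2.21. Among the compounds with values here, the single measured step that touches compound 2 is a number at least 0.79 log units higher from compound 2 to compound 3 (beyond the scatter). Compound 4, `C[n+]1ccn(CCS(C)(=O)=O)c1/C=N/O`, differs from compound 2 in another way: methylsulfonyl in place of cyanomethyl on a saturated chain carbon, two bonds along the chain from an aromatic nitrogen. Within the data shown here, no measured step covers this exchange, and the only guide is the limit of < -3 in this assay, at which 1 of the 3 values shown sits, so the outcome is uncertain. Compound 4 is therefore estimated at -3.1, between -3.7 and -2.5, with the expected step that the limit leaves unreadable from compound 2 to compound 4.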

Compound 4, distribution coefficient: -3.5
The estimate for compound 4 lay 0.40 log units above the measured number; the measured number falls inside the stated range.
By their numbers in this assay, from the lowest: compound 4; then compounds 1 and 3 (each within the scatter of the next).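

Within the data shown here, no step from compound 2 to compound 4 can be read, because the value of compound 2 is only a limit: the limit of < -3 in this assay, at which 1 of the 4 values shown sits. The compounds shown leave open how methylsulfonyl compares with cyanomethyl at this place on the chain.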